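The source may report more compounds than this note shows. Statements on the series, on what has been measured and on what is new or still open speak of the compounds shown alone.

Notes on the series. In an assay on isolated protein for displacement of a labelled ligand from melanin-concentrating hormone receptor 1 (Homo sapiens) (a lower number here means a stronger inhibitor, a higher number a weaker inhibitor), compound 3 `CCCc1cc(N)c2cc(NC(=O)/C=C/c3ccc(Br)cc3)ccc2n1` gives 4 nM. Compound 1 `CCCc1ccc(/C=C/C(=O)Nc2ccc3nc(CCC)cc(N)c3c2)cc1` gives 4 nM, and compound 2 `CCCc1cc(N)c2cc(NC(=O)/C=C/c3ccc(N)cc3)ccc2n1` gives 190 nM. Compound 3 thus stands level with compound 1 at the digits reported, the two of them sharing the lowest numbers of the three, and far from compound 2. Compound 4 `CCCc1cc(N)c2cc(NC(=O)/C=C/c3ccc(O)cc3)ccc2n1` remains to be measured; it differs from compound 3 by hydroxy in place of bromo on an aromatic carbon. Among the compounds with values here, two steps bear on this position: no change at the digits printed from compound 1 to compound 3 (within the scatter), which left the number unchanged, and a 48-fold lower number from compound 2 to compound 3 (1.68 log units; beyond the scatter), which was large. The entering hydroxy group is judged closer to the amino case of compound 2 than to the propyl or bromo cases of compounds 1 and 3, so a higher number is expected for compound 4, though perhaps not as high as the number of compound 2. The step expected is a 13-fold higher number from compound 3 to compound 4 (1.10 log units; beyond the scatter). Compound 4 is estimated at 50 nM, with a range from 10 nM to 250 nM.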

Compound 4, half-maximal inhibitory concentration: 1100 nM
The estimate for compound 4 lay 22-fold (1.34 log units) below the measured number; measured number outside the range, above it.
By their numbers in this assay, from the lowest: compounds 1 and 3 (each within the scatter of the next); then compound 2; then compound 4.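

Working from a 280-fold higher number from compound 3 to compound 4 (2.44 log units; beyond the scatter) in this assay, a swap of bromo for hydroxy alone spans the whole range of the series at this position, and a 280-fold higher number from compound 1 to compound 4 (2.44 log units; beyond the scatter) shows the same gap against propyl. Hydroxy and amino are not interchangeable here, since a 5.8-fold higher number from compound 2 to compound 4 (0.76 log units; beyond the scatter) separates them, although both stand well apart from bromo and propyl. The four groups therefore fall into a low pair, bromo and propyl, and two higher, distinct cases, amino and hydroxy, and no measurement shown here accounts for this order.

Open, going by these compounds, is whether methoxy, which keeps the oxygen of hydroxy but not its hydrogen, falls with hydroxy or with bromo. Also open, on these data alone, is whether chloro or a longer chain such as butyl stays level with bromo and propyl.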